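The compounds below may be only part of what the source reports. "The series", "measured", "known", "first", "only" and "open" are said of these compounds alone.

Measured so far:
- Compound 1 `NC(=O)c1nn([C@@H]2O[C@H](CO)[C@@H](O)[C@H]2O)cc1I`: > 300000 nM (a limit of the assay)
- Compound 2 `COC(=O)c1nn([C@@H]2O[C@H](CO)[C@@H](O)[C@H]2O)cc1I`: 3600 nM

Among the compounds with values here, in a functional assay on ACHN cells (feces, Homo sapiens) (on this read-out higher numbers stand for weaker inhibition and lower numbers for stronger inhibition), compound 2 gives 3600 nM, the only exact number so far. Compound 3 `O=C(O)c1nn([C@@H]2O[C@H](CO)[C@@H](O)[C@H]2O)cc1I` differs from it by hydrogen in place of methyl on an oxygen next to a carbonyl group, which turns methoxycarbonyl into carboxy. Within the data shown here, only one measured step bears on this change: an at least 83-fold lower number from compound 1 to compound 2 (1.92 log units; beyond the scatter), with methoxy in place of amino on a carbonyl carbon. Among the measured compounds shown here, compound 3 also loses the methoxy, so a large step to a higher number is expected in this assay because an at least 83-fold lower number from compound 1 to compound 2 (1.92 log units; beyond the scatter) is the only evidence at this carbonyl carbon. The expected change is a 28-fold higher number from compound 2 to compound 3 (1.44 log units; beyond the scatter). For compound 3 the estimated value is 100000 nM, with an expected range of 10000 nM to 300000 nM.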

Compound 3, half-maximal inhibitory concentration: > 300000 nM
Compound 3 gave a limit, no number; the forecaster's own chance of this, stated with the estimate: 55%; at least 3.0-fold (0.47 log units) between middle value and limit.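

In this assay, hydrogen in place of methyl on an oxygen next to a carbonyl group gives an at least 83-fold higher number from compound 2 to compound 3 (1.92 log units; beyond the scatter), so keeping the oxygen is not enough to hold the measurable inhibition of compound 2. Within the data shown here, compound 3 and compound 1 both end at a limit, not a number, which leaves methoxycarbonyl as the only group here with an exact value: the limit of > 300000 nM in this assay, at which 2 of the 3 values shown sit. The step from compound 1 to compound 3 cannot be read, as both values are limits. Still open, going by these compounds, is whether an ethyl group or a longer chain on this oxygen would keep the inhibition seen with methyl.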